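The compounds below may be only part of what the source reports. "The series", "measured", "known", "first", "only" and "open" are said of these compounds alone.

In a functional assay on BGC-823 cells (Homo sapiens) for antiproliferative activity, read by MTT assay, with a stated time of 48 h (on this read-out higher numbers stand for weaker inhibition and lower numbers for stronger inhibition), compound 1 `Fc1ccc(CSc2nnc(-c3cnccn3)n2-c2ccccc2)cc1` gives 27200 nM. Compound 2 `Fc1cccc(F)c1CSc1nnc(-c2cnccn2)n1-c1ccccc1` reads > 50000 nM, which is a limit and not a number. Compound 3 `c1ccc(CSc2nnc(-c3cnccn3)n2-c2ccccc2)cc1` differs from compound 2 by phenyl in place of 2,6-difluorophenyl on a saturated chain carbon bound to a sulfur, with phenyl in place of 2,6-difluorophenyl on a saturated chain carbon bound to a sulfur. For the measured compounds named here, only one measured step bears on this change, an at least 1.8-fold higher number from compound 1 to compound 2 (0.26 log units; that floor lies within the scatter), and it also concerns the group on that carbon. A small move towards lower numbers in this assay is therefore expected, with the estimated step being an at least 1.5-fold lower number from compound 2 to compound 3 (0.18 log units; that floor lies within the scatter). Compound 3 is expected at 33000 nM, within an estimated range of 14000 nM to 50000 nM.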

Compound 3, half-maximal inhibitory concentration: > 50000 nM
Compound 3 ended at the assay's limit; the forecaster's own chance of this, stated with the estimate: 30%; at least 1.5-fold (0.18 log units) between middle value and limit.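

In this assay compound 3 reads > 50000 nM, which is a limit of the assay and not a number. Benzyl therefore gives no readable value here, and the only readable step is an at least 1.8-fold higher number from compound 1 to compound 3 (0.26 log units; that floor lies within the scatter). The step from compound 2 to compound 3 cannot be read: the limit of > 50000 nM in this assay, at which 2 of the 3 values shown sit.

As far as these compounds go, how far the numbers on this carbon can move remains open, since only compound 1 gives a number. A benzyl carrying an amine or a carboxylic acid, or a longer chain in its place, could show whether any readable trend exists.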